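A few compounds are considered here, and "the series" means these few. Any claim that something is new, unique, unknown or untested is made for them only; others in the source may bear on it.

Compound 1 `Oc1ccc(-c2nnc(Nc3ncccn3)o2)cc1`: 63.4%
Compound 2 `Fc1ccc(-c2nnc(Nc3ncccn3)o2)cc1`: 41.9%

In a functional assay, with a stated time of 30 min, tested at 20 uM (on this read-out lower numbers stand for less inhibition and higher numbers for more inhibition at the one concentration tested (going by the name of the read-out)), compound 2 gives 41.9%, the lower of the two numbers measured. For the measured compounds named here, the single step measured, a number 21.5 percentage points lower from compound 1 to compound 2 (beyond the scatter), lies beyond the scatter. Compound 3 `Clc1ccc(-c2nnc(Nc3ncccn3)o2)cc1` differs from compound 2 by chloro in place of fluoro on an aromatic carbon. Going by the values given here, no measured step exchanges one halogen for another, so the step from compound 1 to compound 2 bears only loosely on this change. The step expected is a number 4.1 percentage points higher from compound 2 to compound 3 (within the scatter), not clearly beyond the scatter. In this assay compound 3 is estimated at 46%, with a range from 26% to 66%.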

Compound 3, a percentage reported as inhibition, at one concentration (the size of the read-out at that concentration, not a potency): 46.2%
Compound 3: the middle estimate sits 0.2 percentage points below what was measured, and the stated range covers the measured number.
By their numbers in this assay, from the lowest: compounds 2 and 3 (each within the scatter of the next); then compound 1.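

In this assay, the exchange of fluoro for chloro on this aromatic carbon gives a number 4.3 percentage points higher from compound 2 to compound 3 (within the scatter), so the two halogens cannot be told apart here. Chloro also falls short of hydroxy, with a number 17.2 percentage points lower from compound 1 to compound 3 (beyond the scatter), which means that the gap first seen with fluoro is seen with a second halogen. No evidence at hand bears on why hydroxy stands apart from both halogens. The compounds shown leave open whether an amine or a methoxy group at this position would read like hydroxy or like the halogens.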